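Cyclopentyl in Place of Propyl on the Shared Core

The compounds below may be only part of what the source reports. "The series", "measured", "known", "first", "only" and "open" are said of these compounds alone.

Of the compounds shown here, two have been measured in an assay on membranes from HEK293 cells for displacement of a labelled ligand from adenosine receptor A2b (Homo sapiens), read by scintillation counting, with a stated time of 30 min; a lower number here means a stronger inhibitor, a higher number a weaker inhibitor. Compound 1 `CCCOC(=O)C1=C(C)NC(=O)NC1c1ccoc1` gives 1190 nM. Within the data shown here, compound 2 `CCCOC(=O)C1=C(C)NC(=O)NC1c1ccsc1` gives 201 nM; the single change between these two is thiophen-3-yl in place of furan-3-yl on a saturated ring carbon, and it produced a 5.9-fold lower number from compound 1 to compound 2 (0.77 log units; beyond the scatter). Among the measured compounds shown here, compound 2 therefore holds the lowest of the two numbers so far, with compound 1 as its only neighbour.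

Compound 3 `CC1=C(C(=O)OC2CCCC2)C(c2ccsc2)NC(=O)N1` keeps the thiophen-3-yl group and the core of compound 2 and changes only the group on the oxygen next to a carbonyl group: cyclopentyl in place of propyl on an oxygen next to a carbonyl group. For the measured compounds named here, the one measured step concerns the aromatic ring on a saturated ring carbon, not the oxygen next to a carbonyl group, so no measured step speaks to this change, and nothing in the data shows how that group influences this assay.

Going by the values given here, with no bearing step, the expected outcome for compound 3 is no step beyond the scatter, and compound 3 is estimated at 180 nM with a range of 50 nM to 650 nM. That estimate means an expected step of a 1.1-fold lower number from compound 2 to compound 3 (0.05 log units; within the scatter), staying within the usual scatter.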

Compound 3, inhibition constant: 659 nM
Beside the measured number, compound 3's estimate is 3.7-fold (0.56 log units) below it, and the stated range ends below it.
By their numbers in this assay, from the lowest: compound 2; then compounds 3 and 1 (each within the scatter of the next).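

In this assay, the group on the oxygen next to a carbonyl group turns out to count: with the thiophen-3-yl group and the shared core held fixed, cyclopentyl in place of propyl gives a 3.3-fold higher number from compound 2 to compound 3 (0.52 log units; beyond the scatter). So the number depends on this position as well as on the aromatic ring that the earlier step changed, and here going from an open chain of 3 heavy atoms to a ring-bearing group of 5 heavy atoms moved the number up, in this one pair only. Nothing available explains why this swap gives a weaker inhibitor.

The compounds shown leave open whether the ring itself or simply the extra carbons matter, which a pentyl chain or a cyclobutyl group on the same oxygen could separate, and whether a shorter group such as ethyl or methyl would take the number the other way. They also leave open whether the same swap would give a similar step with the furan-3-yl group of compound 1 in place of the thiophen-3-yl group.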